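From 3-hydroxyphenyl to pyridin-4-yl

A few compounds are considered here, and "the series" means these few. Any claim that something is new, unique, unknown or untested is made for them only; others in the source may bear on it.

Compound 1 `COc1ccc(/C=C/C[C@H]2C[C@@H]([C@@H](O)c3ccccc3)CO[C@@H]2c2ccccc2)cc1` gives 9010 nM
Compound 2 `O[C@@H](c1ccccc1)[C@H]1CO[C@H](c2ccccc2)[C@@H](C/C=C/C2CCCC2)C1` gives 9060 nM
Compound 3 `Oc1cccc(/C=C/C[C@H]2C[C@@H]([C@@H](O)c3ccccc3)CO[C@@H]2c2ccccc2)c1` gives 12800 nM

All three values come from a functional assay on HL-60 cells (Homo sapiens) for cytotoxicity, read by WST assay, with a stated time of 48 h (a higher number here means a weaker inhibitor, a lower number a stronger inhibitor), and compound 3 sits within the scatter of both others, so the three cannot be ranked. Compound 4 `O[C@@H](c1ccccc1)[C@H]1CO[C@H](c2ccccc2)[C@@H](C/C=C/c2ccncc2)C1` carries pyridin-4-yl in place of 3-hydroxyphenyl on a double-bonded chain carbon bound to a double-bonded chain carbon. Three measured steps changed this same place. Cyclopentyl replacing 4-methoxyphenyl moved the number little (a 1.0-fold higher number from compound 1 to compound 2 (0.00 log units; within the scatter)), as did 3-hydroxyphenyl replacing 4-methoxyphenyl (a 1.4-fold higher number from compound 1 to compound 3 (0.15 log units; within the scatter)) and 3-hydroxyphenyl replacing cyclopentyl (a 1.4-fold higher number from compound 2 to compound 3 (0.15 log units; within the scatter)). None of these steps brought in a ring with a hetero atom, so they guide only loosely. The expected step in this assay is none beyond the scatter (a 1.3-fold lower number from compound 3 to compound 4 (0.11 log units; within the scatter)). For compound 4 the estimate is 10000 nM (expected range 5000 nM to 20000 nM).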

Compound 4, half-maximal inhibitory concentration: > 100000 nM
Compound 4: no number, only a limit; the forecaster's own chance of this, stated with the estimate: 8%; at least 10-fold (1.00 log units) between middle value and limit.
By their numbers in this assay, from the lowest: compounds 1, 2 and 3 (each within the scatter of the next). At a limit, above all of these: compound 4.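

The earlier swaps at this place on the chain all stayed within the scatter, but pyridin-4-yl moves the number beyond it against each of the other three groups (an at least 7.8-fold higher number from compound 3 to compound 4 (0.89 log units; beyond the scatter)) and (an at least 11-fold higher number from compound 2 to compound 4 (1.04 log units; beyond the scatter)) and (an at least 11-fold higher number from compound 1 to compound 4 (1.04 log units; beyond the scatter)). So this position does respond to the group it carries, although 4-methoxyphenyl, cyclopentyl and 3-hydroxyphenyl could not be told apart. The value of compound 4 is a limit and not a number: (the limit of > 100000 nM in this assay, at which 1 of the 4 values shown sits).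

The compounds shown leave open whether the ring nitrogen alone accounts for this step. Pyridin-3-yl or a phenyl ring carrying an amine at this place could help to separate that.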